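A Chloro Swapped for Hydrogen on the Benzyl Group

The source may hold more compounds than are shown below. What is called first, only, known or untested is meant among the compounds shown, and "the series" means these compounds.

Measured values from a functional assay on HCT-116 cells (Homo sapiens) for inhibition, read by fluorescence, with a stated time of 48 h (a lower number here means a stronger inhibitor of growth, a higher number a weaker inhibitor of growth), follow
compound 1 `CC(C)[C@H](N)C(=O)OCCCOC1(c2ccc(Cl)cc2)c2ccccc2C(=O)N1Cc1ccc(Cl)cc1` gives 60000 nM in this test
compound 2 `CC(C)(COC(=O)[C@@H](N)c1ccccc1)COC1(c2ccc(Cl)cc2)c2ccccc2C(=O)N1Cc1ccccc1` gives 44000 nM in this test
compound 3 `CC(C)(CO)COC1(c2ccc(Cl)cc2)c2ccccc2C(=O)N1Cc1ccc(Cl)cc1` gives 65000 nM in this test

Compound 1 sits among three values that all lie within the usual scatter of one another, so none of the three stands apart. Compound 4 `CC(C)[C@H](N)C(=O)OCCCOC1(c2ccc(Cl)cc2)c2ccccc2C(=O)N1Cc1ccccc1` has not yet been measured. It differs from compound 1 by the change hydrogen in place of chloro on an aromatic carbon in which hydrogen takes the place of chloro on an aromatic carbon, so that 4-chlorobenzyl becomes benzyl.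

For the measured compounds named here, no measured step isolates this change. Going by the values given here, the only step available, a 1.1-fold higher number from compound 1 to compound 3 (0.03 log units; within the scatter), replaces the side chain and keeps the 4-chlorobenzyl group, so it bears on the new change only indirectly. Compound 2 already carries benzyl, although on a different side chain, and compound 2 gives 44000 nM in this assay, which is within the scatter of the value for compound 1. On this evidence, no step beyond the scatter is expected in this assay and no firm direction can be given. The expected size is a 1.1-fold lower number from compound 1 to compound 4 (0.04 log units; within the scatter) on this limited evidence. Compound 4 is estimated to give 55000 nM with an expected range of 28000 nM to 110000 nM in this test.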

Compound 4, concentration for 50% growth inhibition: 65000 nM
Compound 4: the middle estimate sits 1.2-fold (0.07 log units) below what was measured; measured number inside the range.
By their numbers in this assay, from the lowest: compounds 2, 1, 3 and 4 (each within the scatter of the next).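

A single pair now isolates hydrogen in place of chloro on this aromatic carbon: in this assay the pair gives a 1.1-fold higher number from compound 1 to compound 4 (0.03 log units; within the scatter) and so shows no difference that this test can separate from the usual scatter. For the compounds shown here, with the side chain of compound 1 held fixed, 4-chlorobenzyl and benzyl therefore cannot be told apart here, which the earlier compounds could suggest only indirectly, as each of them also differs in its side chain. Nothing among the available data offers an explanation for this result.

This reading rests on one pair with one side chain, and whether the same swap would read alike on the side chains of compound 2 or compound 3 remains open, as neither has a partner among the compounds shown that differs from it in this one place. Also open, on these data alone, is how a fluoro, a methoxy or an amine at this same place would read, and whether any such group would give a step beyond the scatter.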